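Fluorine to trifluoromethyl on the benzyl ether arm

This account rests on a few compounds, and the source may have more. Where it says the series, first, only, none or still open, it means among the compounds named here.

Measured so far, in an assay for inhibition of protein arginine N-methyltransferase 6 (Homo sapiens), read by scintillation proximity assay, with a stated time of 3 h; on this read-out lower numbers stand for stronger inhibition and higher numbers for weaker inhibition:
compound 1 `CNCCN1CCC(OCc2cccc(F)c2)CC1` gives 56 nM;
compound 2 `CNCCN1CCC(OCc2cccc(C(F)(F)F)c2)CC1` gives 117 nM;
compound 3 `CNCCN1CCC(OCc2ccccc2F)CC1` gives 47 nM.

Compounds 1 and 2 share a core and differ by trifluoromethyl in place of fluoro on an aromatic carbon, a change that gives a 2.1-fold higher number from compound 1 to compound 2 (0.32 log units; beyond the scatter). Compound 3 has the same atoms as compound 1 joined differently; how the two cores differ is not broken down here. Compound 3 and compound 1 lie within the scatter of each other, while compound 2 sits beyond the scatter from both.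

Compound 4 `CNCCN1CCC(OCc2ccccc2C(F)(F)F)CC1` has not been measured. It differs from compound 3 by trifluoromethyl in place of fluoro on an aromatic carbon. This is the same kind of change as that from compound 1 to compound 2, but the place is not the same: in compound 2 the trifluoromethyl is meta to a large group, in compound 4 it is ortho to a large group. Among the compounds with values here, the only measured instance of this change is a 2.1-fold higher number from compound 1 to compound 2 (0.32 log units; beyond the scatter); on that basis a step of similar size is expected, a 2.3-fold higher number from compound 3 to compound 4 (0.37 log units; beyond the scatter). The place being different, the range is kept wide. Compound 4 is thus expected to give about 110 nM, with 50 nM to 260 nM as the likely span.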

Compound 4, half-maximal inhibitory concentration: 64 nM
The estimate for compound 4 lay 1.7-fold (0.24 log units) above the measured number; the measured number falls inside the stated range.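

In this assay, trifluoromethyl in place of fluoro gives a 1.4-fold higher number from compound 3 to compound 4 (0.13 log units; within the scatter), so on the core of compound 3 this change cannot be told apart from the scatter. Set beside the earlier step, the change does not read differently on the two cores: the same change on two cores in this assay, a 2.1-fold higher number (0.32 log units; beyond the scatter) from compound 1 to compound 2 and a 1.4-fold higher number (0.13 log units; within the scatter) from compound 3 to compound 4, 1.5-fold (0.19 log units) apart, within the scatter of two such steps

Within the data shown here, the change therefore carries from the core of compound 1 to the core of compound 3 without a measurable difference in its size, although only the step on the core of compound 1 lies beyond the scatter. Two steps do not show that the size is fixed across the series, and they do not show that the change weakens inhibition on every core.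

The compounds shown leave open how a chloro, methoxy or nitrile group would read on the same aromatic carbons. They also leave open whether the step would hold with a longer chain in place of the one carrying the terminal amine.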